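Amide aryl variation in the antiproliferative series

The compounds below may be only part of what the source reports. "The series", "measured", "known", "first", "only" and "open" are said of these compounds alone.

Compound 3 `Cc1cc(C(=O)Nc2cccc(-c3oc4cc(-c5ccc(F)cc5)ccc4c(=O)c3O)c2)ccc1F` gives the highest number of the three measured in a functional assay on HeLa cells (Homo sapiens) for antiproliferative activity, read by CCK-8 assay, with a stated time of 72 h (on this read-out lower numbers stand for stronger inhibition and higher numbers for weaker inhibition), at 18900 nM. Compound 1 `COc1ccc(C(=O)Nc2cccc(-c3oc4cc(-c5ccc(F)cc5)ccc4c(=O)c3O)c2)cc1` gives 4820 nM and compound 2 `O=C(Nc1cccc(-c2oc3cc(-c4ccc(F)cc4)ccc3c(=O)c2O)c1)c1ccc(Cl)cc1` gives 3670 nM; the step of a 1.3-fold lower number from compound 1 to compound 2 (0.12 log units; within the scatter) is within the scatter. Compound 4 `Cc1cc(C)cc(C(=O)Nc2cccc(-c3oc4cc(-c5ccc(F)cc5)ccc4c(=O)c3O)c2)c1` carries 3,5-dimethylphenyl in place of 4-fluoro-3-methylphenyl on a carbonyl carbon. Among the measured compounds shown here, the steps bearing on it are a 3.9-fold higher number from compound 1 to compound 3 (0.59 log units; beyond the scatter) and a 5.1-fold higher number from compound 2 to compound 3 (0.71 log units; beyond the scatter), both modest rises ending at compound 3; no measured step removes the fluorine alone or adds a second methyl, so the direction of the new step is not settled by the data. The expected step is a 1.6-fold lower number from compound 3 to compound 4 (0.20 log units; within the scatter), a partial reversal, though a step within the scatter is also plausible. For compound 4 the estimate is 12000 nM, with a range from 4000 nM to 36000 nM.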

Compound 4, half-maximal inhibitory concentration: 5540 nM
Compound 4: the middle estimate sits 2.2-fold (0.34 log units) above what was measured; the range from low to high includes it.
By their numbers in this assay, from the lowest: compounds 2, 1 and 4 (each within the scatter of the next); then compound 3.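

On the carbonyl carbon, 3,5-dimethylphenyl in place of 4-fluoro-3-methylphenyl gives a clear gain (a 3.4-fold lower number from compound 3 to compound 4 (0.53 log units; beyond the scatter)), so a methyl-bearing aryl group does not by itself carry the weak number of compound 3. The steps from the other two amides (a 1.5-fold higher number from compound 2 to compound 4 (0.18 log units; within the scatter) and a 1.1-fold higher number from compound 1 to compound 4 (0.06 log units; within the scatter)) lie within the scatter, so three of the four aryl groups match, and only 4-fluoro-3-methylphenyl, in compound 3, stands apart. No measurement bears on the reason for this gap.

Open: whether an amine, a carboxylic acid or a longer chain on this aryl ring would move the number beyond this shared level.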